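The source may report more compounds than this note shows. Statements on the series, on what has been measured and on what is new or still open speak of the compounds shown alone.

Compound 2 `COc1cc(OC)c(/C=C/S(=O)(=O)Nc2ccc(OC)c(O)c2)c(OC)c1` holds the lowest of the three numbers in a functional assay on K562 cells (Homo sapiens) for cytotoxicity, read by trypan blue exclusion, with a stated time of 96 h; on this read-out higher numbers stand for weaker inhibition and lower numbers for stronger inhibition; in this assay compound 2 gives 15 nM. Compound 1 `O=S(=O)(/C=C/c1ccc(Br)cc1)Nc1ccc(F)cc1` gives 10000 nM in this assay, and compound 3 `COc1ccc(NS(=O)(=O)/C=C/c2c(OC)cc(OCCCC(=O)O)cc2OC)cc1O` gives 10000 nM. Compound 4 `COc1cc(OC)c(/C=C/S(=O)(=O)Nc2ccc(OC)c(NC(C)C(=O)O)c2)c(OC)c1` has not been measured; it differs from compound 2 by (1-carboxyethyl)amino in place of hydroxy on an aromatic carbon, the site being ortho to a methoxy group and meta to a large group. For the measured compounds named here, one measured step bears on it: a 670-fold higher number from compound 2 to compound 3 (2.82 log units; beyond the scatter), where a chain ending in a carboxylic acid entered at another part of the shared core. Compound 4 likewise gains a carboxylic-acid-bearing group, so a large upward step in this assay is expected, though with wide uncertainty. Compound 4 is therefore expected near 2000 nM, between 200 nM and 10000 nM, an expected step of a 130-fold higher number from compound 2 to compound 4 (2.12 log units; beyond the scatter).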

Compound 4, half-maximal inhibitory concentration: 8 nM
Estimate against measurement, compound 4: 250-fold (2.40 log units) above; measured number below the stated range.
By their numbers in this assay, from the lowest: compounds 4 and 2 (each within the scatter of the next); then compounds 1 and 3 (each within the scatter of the next).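

At the aromatic carbon ortho to a methoxy group, the step to (1-carboxyethyl)amino in place of hydroxy is a 1.9-fold lower number from compound 2 to compound 4 (0.27 log units; within the scatter) in this assay, so this position accepts the larger group without a change beyond the scatter. A carboxylic acid in the molecule therefore does not by itself bring the large rise of a 670-fold higher number from compound 2 to compound 3 (2.82 log units; beyond the scatter), which arose at another part of the shared core. Nothing measured here accounts for this difference between the two sites. Open, on these data alone, is whether an amine without the carboxylic acid, or a longer chain ending in a carboxylic acid, would be accepted at this carbon.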